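Swapping trifluoromethyl for fluoro on the aryl hydrazone

The source may report more compounds than this note shows. Statements on the series, on what has been measured and on what is new or still open speak of the compounds shown alone.

Measured compounds and their values:
- compound 1, `O=C(N/N=C/c1ccccc1)c1cnccn1`: 60.8%
- compound 2, `CC(C)c1ccc(/C=N/NC(=O)c2cnccn2)cc1`: 66.5%
- compound 3, `O=C(N/N=C/c1ccc(C(F)(F)F)cc1)c1cnccn1`: 27.7%

Three hydrazones sharing one core were tested in a functional assay on the whole organism (strain Swiss) for inhibition, with Mus musculus as the target, in the formalin test, with stated times of 40 min and 30 min, at a dose of 100 umol/kg by the oral route; on this read-out higher numbers stand for more inhibition at the one dose given (going by the name of the read-out) and lower numbers for less inhibition. Compound 1 carries hydrogen on the aromatic carbon in question, compound 2 isopropyl and compound 3 trifluoromethyl. Compound 3 stands lowest of the three numbers: the nearest is compound 1, the furthest compound 2, and both gaps lie beyond the scatter. The change from compound 1 to compound 2 was a number 5.7 percentage points higher from compound 1 to compound 2 (within the scatter), so hydrogen and isopropyl cannot be told apart here.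

Compound 4, `O=C(N/N=C/c1ccc(F)cc1)c1cnccn1`, has not yet been measured in this assay. It differs from compound 3 in one place: fluoro in place of trifluoromethyl on an aromatic carbon. The relevant measured steps both end at trifluoromethyl: a number 33.1 percentage points lower from compound 1 to compound 3 (beyond the scatter) and a number 38.8 percentage points lower from compound 2 to compound 3 (beyond the scatter). Taking trifluoromethyl away therefore points upward, but no measured compound carries fluoro, so the size of the rise is uncertain; fluoro may sit somewhere between hydrogen and trifluoromethyl. Compound 4 is expected to show a number 22.3 percentage points higher from compound 3 to compound 4 (beyond the scatter), landing near 50%, with a range from 30% to 70%.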

Compound 4, a percentage reported as inhibition, in the whole organism at one dose (the size of the read-out at that dose, not a potency): 72.3%
Compound 4: the middle estimate sits 22.3 percentage points below what was measured; the measured number lies above the stated range.
By their numbers in this assay, from the lowest: compound 3; then compounds 1, 2 and 4 (each within the scatter of the next, the first and the last beyond it).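

In this assay, fluorine on this aromatic carbon does not by itself go with a low number: replacing trifluoromethyl with fluoro gives a number 44.6 percentage points higher from compound 3 to compound 4 (beyond the scatter), so the drop seen with compound 3 does not extend to this single fluorine atom. Fluoro also gives the first upward step beyond the scatter from the unsubstituted compound at this position, a number 11.5 percentage points higher from compound 1 to compound 4 (beyond the scatter), although this step is modest. Against isopropyl, the result is a number 5.8 percentage points higher from compound 2 to compound 4 (within the scatter), so these two groups cannot be told apart here, just as isopropyl and hydrogen could not, and only hydrogen and fluoro are separated among these three compounds.

No measurement at hand speaks to what separates fluoro from trifluoromethyl. From the compounds shown here alone, it remains open whether chloro, methoxy, an amine or a carboxylic acid on this carbon would give a number close to that of compound 3 or to those of the other three compounds, and whether fluoro on a different carbon of the ring would match compound 4.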